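This account rests on a few compounds, and the source may have more. Where it says the series, first, only, none or still open, it means among the compounds named here.

Compound 1 `COC(=O)[C@]1(O)C[C@@H](O)[C@@H](O)[C@H](OC(=O)/C=C\c2ccc(O)c(O)c2)C1` and compound 2 `COC(=O)[C@]1(O)C[C@@H](O)[C@@H](O)[C@H](OC(=O)/C=C/c2ccc(O)cc2)C1` share the same core and differ only in the ester-linked side chain. In a functional assay on BV-2 cells (Mus musculus) for inhibition, read by Griess assay, with a stated time of 10 min (a higher number here means a weaker inhibitor, a lower number a stronger inhibitor), compound 1 gives 17000 nM, while in this assay compound 2 gives 82000 nM. Of these two numbers compound 2 holds the highest, and the gap down to compound 1 lies beyond the usual scatter. Among the measured compounds shown here, because the two differ in more than one place, their values alone show no single step. Compound 3 `COC(=O)[C@]1(O)C[C@@H](O)[C@@H](O)[C@H](OC(=O)/C=C\c2ccc(O)cc2)C1` has not been measured yet. Its difference from compound 2 is the two compounds have the same atoms and bonds and differ only in configuration as drawn: 1 of 5 stereo elements differ; a double bond is drawn E in compound 2 and Z in compound 3. For the measured compounds named here, no measured pair shows this change on its own, so its direction is open; on the evidence at hand the expected step is a 1.4-fold lower number from compound 2 to compound 3 (0.14 log units; within the scatter), a small drift with wide uncertainty. Compound 3 is therefore estimated to give about 60000 nM, plausibly anywhere from 20000 nM to 200000 nM.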

Compound 3, half-maximal inhibitory concentration: 86400 nM
The estimate for compound 3 lay 1.4-fold (0.16 log units) below the measured number; measured number inside the range.
By their numbers in this assay, from the lowest: compound 1; then compounds 2 and 3 (each within the scatter of the next).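

In this assay, the geometry of the double bond makes no difference that can be told apart, with a 1.1-fold higher number from compound 2 to compound 3 (0.02 log units; within the scatter). Among the compounds shown here, compound 3 also isolates the aromatic hydroxy group for the first time: with hydrogen in place of hydroxy on an aromatic carbon, there is a 5.1-fold higher number from compound 1 to compound 3 (0.71 log units; beyond the scatter), so here the extra hydroxy of compound 1 goes with stronger inhibition. The double-bond comparison involves no other structural change: the fact that compounds 2 and 3 differ only in the configuration as drawn.

The compounds shown leave open whether a methoxy group or a fluorine atom on that aromatic carbon would preserve the stronger inhibition seen with hydroxy. They also leave open how a free carboxylic acid in place of the methyl ester on the shared core would affect the number.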